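The source may hold more compounds than are shown below. What is called first, only, known or untested is meant among the compounds shown, and "the series" means these compounds.

Compound 1 `C#CCOC(=O)NN=C1C(Cl)=C(Cl)C(Cl)=C1Cl`: 800 nM
Compound 2 `CC(C)(C)NN=C1C(Cl)=C(Cl)C(Cl)=C1Cl`: > 3000 nM
Compound 3 `ClC1=C(Cl)C(Cl)=C(Cl)C1=NN(c1ccccc1)c1ccccc1`: > 3000 nM

For the measured compounds named here, in a functional assay on RPMI-8226 cells (Homo sapiens) for cytotoxicity, read by MTT assay, with a stated time of 48 h (on this read-out lower numbers stand for stronger inhibition and higher numbers for weaker inhibition), compound 1 gives 800 nM, and it is the only compound in this small set with an actual number. Compound 2 stands at > 3000 nM, which is a limit of the assay and not a number. Compound 3 stands at > 3000 nM, which is also a limit.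

Compound 4 `CC(C)(C)OC(=O)NN=C1C(Cl)=C(Cl)C(Cl)=C1Cl` has not yet been measured. It keeps the core of compound 1 and differs from it in one place: tert-butyl in place of propargyl on an oxygen next to a carbonyl group. In words, this puts tert-butyl in place of propargyl on an oxygen next to a carbonyl group.

Going by the values given here, no measured pair in the set differs in a single place, so no measured step gives the size of this change. Compound 1 at 800 nM is the only anchor for the expectation. A small move toward weaker inhibition in this assay is expected, possibly none beyond the usual scatter. The expected step is a 1.4-fold higher number from compound 1 to compound 4 (0.14 log units; within the scatter). For compound 4 the estimated value is 1100 nM, with an expected range from 400 nM to 3000 nM.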

Compound 4, half-maximal inhibitory concentration: 100 nM
Estimate against measurement, compound 4: 11-fold (1.04 log units) above, outside the stated range (below it).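

In this assay the change to tert-butyl in place of propargyl on an oxygen next to a carbonyl group gives an 8.0-fold lower number from compound 1 to compound 4 (0.90 log units; beyond the scatter) and so shows that the read-out responds to the group at this place. For the compounds shown here, this is the first step that can be read in the set, and it also shows that the triple bond of propargyl is not needed for a value in this range, since compound 4 carries none and has the lower number. Going by these compounds alone, compound 2 and compound 3 each stand at a limit and not at a number, so no step involving them can be read: the limit of > 3000 nM in this assay, at which 2 of the 4 values shown sit.

One pair cannot tell whether this gain belongs to tert-butyl alone or would also appear with another group on this oxygen, such as methyl, isopropyl or benzyl. It also remains open how an amine nitrogen in place of this oxygen would read, and nothing shown gives a reason for the size of the step.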